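Chain length at the hydrazide in a fused bicyclic series

The source may hold more compounds than are shown below. What is called first, only, known or untested is meant among the compounds shown, and "the series" means these compounds.

Measured so far:
compound 1 `CC(=O)NNC(=O)c1csc2ncc(-c3ccc(C)cc3)n12` gives 92700 nM
compound 2 `CCC(=O)NNC(=O)c1csc2ncc(-c3ccc(C)cc3)n12` gives 18500 nM
compound 3 `CCC(=O)NNC(=O)c1csc2ncc(-c3ccc(Br)cc3)n12` gives 43700 nM

All three were run in a functional assay on PC-3 cells (Homo sapiens) for antiproliferative activity, read by MTT assay, with a stated time of 72 h; on this read-out higher numbers stand for weaker inhibition and lower numbers for stronger inhibition. Among the compounds with values here, the one change already seen twice in the set is methyl in place of hydrogen on a saturated chain carbon bound to a carbonyl carbon; made once, it gave a 5.0-fold lower number from compound 1 to compound 2 (0.70 log units; beyond the scatter). Within the data shown here, the cores of compound 1 and compound 3 are not the same, and the difference between the two cores is not broken down here; among the measured pairs, a 2.4-fold higher number from compound 2 to compound 3 (0.37 log units; beyond the scatter) is the only step that touches the aromatic substituent.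

Compound 4 `CCCC(=O)NNC(=O)c1csc2ncc(-c3ccc(Br)cc3)n12` is not yet measured. It differs from compound 3 by methyl in place of hydrogen on a saturated chain carbon, two bonds along the chain from a carbonyl carbon. Among the measured compounds shown here, this is the same kind of change as the one from compound 1 to compound 2, but the place is not the same: there the entering group sat on a saturated chain carbon bound to a carbonyl carbon, whereas here it sits on a saturated chain carbon, two bonds along the chain from a carbonyl carbon.

For the measured compounds named here, because compound 1 to compound 2 gave a 5.0-fold lower number from compound 1 to compound 2 (0.70 log units; beyond the scatter), a step in the same direction is expected for compound 4, though a smaller one, since the added carbon now lies one bond further from the carbonyl and the only precedent is a single pair. In this assay compound 4 is estimated at 20000 nM, a step of a 2.2-fold lower number from compound 3 to compound 4 (0.34 log units; beyond the scatter), with the expected range 8000 nM to 50000 nM.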

Compound 4, half-maximal inhibitory concentration: 58500 nM
The estimate for compound 4 lay 2.9-fold (0.47 log units) below the measured number; measured number outside the range, above it.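

In this assay, the gain seen on adding a methyl to the chain of the core of compound 1 did not carry over to the core of compound 3: the same change on two cores in this assay, a 5.0-fold lower number (0.70 log units; beyond the scatter) from compound 1 to compound 2 and a 1.3-fold higher number (0.13 log units; within the scatter) from compound 3 to compound 4, 6.7-fold (0.83 log units) apart, beyond the scatter of two such steps

Taken alone, a 1.3-fold higher number from compound 3 to compound 4 (0.13 log units; within the scatter) shows that lengthening propanoyl to propylcarbonyl on the bromo-substituted core gives no step that can be told from the scatter, so the two compounds cannot be ranked on this read-out. What this does not show is why the two steps part: they differ both in the aromatic substituent, methyl in one pair and bromo in the other, and in where the methyl enters the chain, and with a single pair for each step the data cannot separate these two differences.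

The propylcarbonyl chain on the core of compound 2 would be the direct test, since it would hold the aromatic methyl fixed and leave only the place on the chain as the difference. On these data alone, whether a still longer chain, a branched chain, or an amine or a carboxylic acid at the end of the chain would move the number in either direction on either core remains open.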